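Cytotoxicity of pyridyl-thiadiazole thioether amides: phenyl to benzyl

The compounds below may be only part of what the source reports. "The series", "measured", "known", "first", "only" and "open" are said of these compounds alone.

Compound 1 `O=C(CCSc1nnc(-c2ccncc2)s1)Nc1ccccc1` was tested in an ADME assay on HepG2 cells (Homo sapiens) for cytotoxicity, with a stated time of 3 days; a higher number here means that more compound is tolerated, a lower number that less compound is tolerated. In this assay compound 1 gives > 50000 nM, which is a limit of the assay and not a number. Compound 2 `CC(CSc1nnc(-c2ccncc2)s1)C(=O)Nc1ccc(Cl)cc1` likewise reaches only the limit in this assay, at > 50000 nM. For compound 3 `O=C(CSc1nnc(-c2ccncc2)s1)NCc1ccccc1Cl` the result in this assay is "not determined" (no result reported). Among the measured compounds shown here, compound 1 therefore stands at the limit of > 50000 nM in this assay, at which 2 of the 3 values shown sit, with no measured step between compounds to lean on. Compound 4 `O=C(CCSc1nnc(-c2ccncc2)s1)NCc1ccccc1` differs from compound 1 by benzyl in place of phenyl on an amide-type nitrogen. No change beyond the scatter is expected from compound 1 to compound 4, so the estimated step is a step that the limit leaves unreadable from compound 1 to compound 4. Compound 4 is accordingly expected at 60000 nM, in the range 30000 nM to 150000 nM, most likely again reported only as a limit.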

Compound 4, half-maximal cytotoxic concentration: 14000 nM
Beside the measured number, compound 4's estimate is 4.3-fold (0.63 log units) above it, outside the stated range (below it).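

In this assay, benzyl in place of phenyl on an amide-type nitrogen gives an at least 3.5-fold lower number from compound 1 to compound 4 (0.55 log units; beyond the scatter) and so shows that this position can bring the series off the limit. Compound 4 is the only compound shown with a readable number, so anilino to benzylamino is not a neutral change here. Compound 1 gives only a limit, so the step remains a bound: the limit of > 50000 nM in this assay, at which 2 of the 4 values shown sit.

Going by these compounds, how far the number moves with a longer chain stays open. A phenethyl group on the same nitrogen would test whether the trend continues.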